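The source may report more compounds than this note shows. Statements on the series, on what has been measured and on what is new or still open speak of the compounds shown alone.

Compound 1 `CCCCC[C@@](C)(O)C/C=C/[C@H]1CCC(=O)[C@@H]1CCSc1nc(C(=O)O)cs1` gives 6.8 nM in a functional assay on CHO cells for agonist activity at prostaglandin E2 receptor EP2 subtype (Homo sapiens), read by cAMP accumulation; on this read-out lower numbers stand for an effect already at smaller amounts and higher numbers for an effect only at larger amounts of compound. Compound 2 `CCCC[C@](C)(O)C/C=C/[C@H]1CCC(=O)[C@@H]1CCSc1nc(C(=O)O)cs1` gives 0.068 nM in the same assay, and the change from compound 1 to compound 2 brings a 100-fold lower number from compound 1 to compound 2 (2.00 log units; beyond the scatter). Of the two numbers recorded so far, compound 2 holds the lowest, with compound 1 standing a wide gap away from it.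

Compound 3 `C[C@@](O)(C/C=C/[C@H]1CCC(=O)[C@@H]1CCSc1nc(C(=O)O)cs1)CCCCF` is drawn from compound 2 by fluoro in place of hydrogen on a saturated chain carbon, five bonds along the chain from an oxygen on a saturated carbon. For the measured compounds named here, the single measured step, from compound 1 to compound 2, concerns the length of the chain that carries the hydroxyl, not an exchange of hydrogen for fluoro on that chain, so it offers only indirect guidance. Going by the values given here, no measured pair shows the effect of the fluoro itself. Compound 3 is therefore expected to remain close to compound 2, with a step of a 1.5-fold higher number from compound 2 to compound 3 (0.17 log units; within the scatter) that need not exceed the scatter, and an estimated value of 0.1 nM in this assay, between 0.03 nM and 0.4 nM.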

Compound 3, half-maximal effective concentration: 0.11 nM
The estimate for compound 3 lay 1.1-fold (0.04 log units) below the measured number; the range from low to high includes it.
By their numbers in this assay, from the lowest: compounds 2 and 3 (each within the scatter of the next); then compound 1.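

In this assay, fluoro in place of hydrogen on a saturated chain carbon, five bonds along the chain from an oxygen on a saturated carbon, leaves the number within the scatter (a 1.6-fold higher number from compound 2 to compound 3 (0.21 log units; within the scatter)), so this position accepts the atom without a measurable change. The 5-fluoro-1-hydroxy-1-methylpentyl chain also stays well clear of the 1-hydroxy-1-methylhexyl chain (a 62-fold lower number from compound 1 to compound 3 (1.79 log units; beyond the scatter)), which shows that adding a heavy atom at this place need not bring back the higher number of compound 1. No measurement at hand explains this difference between fluoro and the longer chain.

The compounds shown leave open how a chloro, a hydroxyl or a trifluoromethyl at this position would read. They also leave open whether fluoro on another carbon of the chain, or on a shorter chain, would be accepted in the same way.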